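A few compounds are considered here, and "the series" means these few. Any claim that something is new, unique, unknown or untested is made for them only; others in the source may bear on it.

Compound 2 `Cc1nc(Nc2ccc3sc(C(=O)Nc4c(C)cccc4Cl)cc3c2)cc(N2CCN(C)CC2)n1` gives 17000 nM in a functional assay on K562 cells (Homo sapiens) for cytotoxicity, read by MTT assay and WST assay, with a stated time of 72 h (a higher number here means a weaker inhibitor, a lower number a stronger inhibitor), the lowest of the two numbers shown, while compound 1 `Cc1nc(Nc2ccc3sc(C(=O)Nc4c(C)cccc4Cl)cc3c2)cc(N2CCC(C)CC2)n1` gives 22200 nM in this assay; the step of a 1.3-fold lower number from compound 1 to compound 2 (0.12 log units; within the scatter) is within the scatter. Compound 3 `CCN1CCN(c2cc(Nc3ccc4sc(C(=O)Nc5c(C)cccc5Cl)cc4c3)nc(C)n2)CC1` differs from compound 2 by methyl in place of hydrogen on a saturated chain carbon bound to an amine nitrogen in a ring. No measured step alters this chain; the only step shown, a 1.3-fold lower number from compound 1 to compound 2 (0.12 log units; within the scatter), swaps the ring itself and barely moves the number. A step beyond the scatter is therefore not expected, and compound 3 is estimated at 15000 nM, likely between 6000 nM and 40000 nM, meaning a 1.1-fold lower number from compound 2 to compound 3 (0.05 log units; within the scatter).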

Compound 3, half-maximal inhibitory concentration: 16900 nM
Compound 3: the middle estimate sits 1.1-fold (0.05 log units) below what was measured; measured number inside the range.
By their numbers in this assay, from the lowest: compounds 3, 2 and 1 (each within the scatter of the next).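

In this assay, replacing 4-methylpiperazin-1-yl with 4-ethylpiperazin-1-yl gives a 1.0-fold lower number from compound 2 to compound 3 (0.00 log units; within the scatter) and so leaves the number unchanged within the scatter. Set against the piperidine of the first compound, the ethyl compound gives a 1.3-fold lower number from compound 1 to compound 3 (0.12 log units; within the scatter) and again stays within the scatter, so neither this change to the chain nor the wider change of group separates these compounds. Nothing available explains why the number stays flat.

Going by these compounds, a longer chain such as propyl, or a chain ending in a hydroxyl group or a carboxylic acid, remains open at this position. So does whether any change to the group on this ring nitrogen can move the number beyond the scatter.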